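From carbamoyl to diethylcarbamoyl on the shared core

The compounds below may be only part of what the source reports. "The series", "measured", "known", "first", "only" and "open" are said of these compounds alone.

Values in a functional assay with Oryctolagus cuniculus as the target; on this read-out higher numbers stand for weaker inhibition and lower numbers for stronger inhibition:
Compound 1 `COc1ccc(-c2nc(N=C(N)N)sc2-c2ccc(OC)cc2)cc1`: 31000 nM
Compound 2 `COc1ccc(-c2nc(CNC(=O)CSC)sc2-c2ccc(OC)cc2)cc1`: < 100 nM, a limit
Compound 3 `COc1ccc(-c2nc(C(N)=O)sc2-c2ccc(OC)cc2)cc1`: > 1000 nM, a limit

Compound 3 gives > 1000 nM, and this is a limit, not a number. Its position is fixed only in part. The data show a step that the limit leaves unreadable from compound 1 to compound 3, and they also show an at least 10-fold higher number from compound 2 to compound 3 (1.00 log units; beyond the scatter).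

Compound 4 `CCN(CC)C(=O)c1nc(-c2ccc(OC)cc2)c(-c2ccc(OC)cc2)s1` has not yet been measured. It differs from compound 3 by diethylamino in place of amino on a carbonyl carbon, or carbamoyl to diethylcarbamoyl.

Within the data shown here, no measured step makes this exact change. The nearest evidence is the step just given from compound 2, which shows that replacing the longer chain with carbamoyl raises the number. The other is an at least 310-fold lower number from compound 1 to compound 2 (2.49 log units; beyond the scatter), which shows how far a change at this place on the core can move the read-out. The chain of compound 2 is not diethylcarbamoyl, however, so these steps carry over only partly, and compound 3 offers no exact starting number.

The step expected in this assay is an at least 3.3-fold lower number from compound 3 to compound 4 (0.52 log units; beyond the scatter), a modest move towards a lower number. For compound 4 the estimated value is 300 nM, with an expected range from 40 nM to 2500 nM.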

Compound 4, half-maximal inhibitory concentration: < 10 nM
Compound 4 was reported as a limit; the forecaster's own chance of this, stated with the estimate: 35%; middle value at least 30-fold (1.47 log units) from the limit.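

In this assay compound 4 gives < 10 nM, and this value is a limit of the assay, not a number. Among these compounds, putting diethylamino in place of amino on the carbonyl carbon gives an at least 100-fold lower number from compound 3 to compound 4 (2.00 log units; beyond the scatter), which shows that the read-out at this position responds strongly to a change within the amide itself, with the carbonyl and its link to the aromatic carbon kept, whereas the earlier steps had exchanged the whole group on the core. Diethylcarbamoyl in place of the group carried by compound 1 gives an at least 3100-fold lower number from compound 1 to compound 4 (3.49 log units; beyond the scatter), so a chain as long as the one in compound 2 is not needed for a low number on this read-out.

The step between compound 2 and compound 4 cannot be read, and how far the true value of compound 4 lies from its limit also stays unknown: the limit of < 10 nM in this assay, at which 1 of the 4 values shown sits. The compounds shown do not tell whether ethylamino, dimethylamino or a ring amine such as pyrrolidine on the same carbonyl carbon would give a similarly low number.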